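Benzoxazolone propanoic acids: ethyl for ethoxy on the aromatic ring

The source may hold more compounds than are shown below. What is called first, only, known or untested is meant among the compounds shown, and "the series" means these compounds.

Measured so far:
- compound 1 `O=C(O)CCn1c(=O)oc2cc(OCc3ccccc3)c(Cl)cc21` gives 1580 nM in an assay on HEK293 cells for inhibition of kynurenine 3-monooxygenase (Homo sapiens), read by LC-MS, with a stated time of 20 h; on this read-out lower numbers stand for stronger inhibition and higher numbers for weaker inhibition
- compound 2 `O=C(O)CCn1c(=O)oc2cc(OCc3ccccn3)c(Cl)cc21` gives 5010 nM in this assay
- compound 3 `CCOc1cc2oc(=O)n(CCC(=O)O)c2cc1Cl` gives 398 nM in this assay

Compound 3 stands lowest of the three numbers; its nearest neighbour is compound 1, a 4.0-fold lower number from compound 1 to compound 3 (0.60 log units; beyond the scatter), and compound 2 lies furthest, a 13-fold lower number from compound 2 to compound 3 (1.10 log units; beyond the scatter). Within the measured set the only variable is the group on the saturated chain carbon bound to the oxygen on the aromatic ring: pyridin-2-yl for phenyl gave a 3.2-fold higher number from compound 1 to compound 2 (0.50 log units; beyond the scatter), and methyl for phenyl gave a 4.0-fold lower number from compound 1 to compound 3 (0.60 log units; beyond the scatter).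

Compound 4 `CCc1cc2oc(=O)n(CCC(=O)O)c2cc1Cl` differs from compound 3 by ethyl in place of ethoxy on an aromatic carbon. Going by the values given here, no measured step touches this position or removes the oxygen from the aromatic ring, so none of the three steps bears directly on it; they only show that the smaller substituent at the ether side gave the lower numbers. On these data alone, the ether oxygen is present in every measured compound, so its removal is untested. The step to compound 4 is expected to be small to modest, with weakening as the more likely direction, a 2.3-fold higher number from compound 3 to compound 4 (0.35 log units; beyond the scatter). Compound 4 is therefore estimated at 900 nM in this assay, within 250 nM to 4000 nM.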

Compound 4, half-maximal inhibitory concentration: 316 nM
Compound 4: the middle estimate sits 2.8-fold (0.45 log units) above what was measured; the range from low to high includes it.
By their numbers in this assay, from the lowest: compounds 4 and 3 (each within the scatter of the next); then compound 1; then compound 2.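

In this assay, removing the ether oxygen at this aromatic carbon, ortho to a chloro group, leaves no change that can be read: a 1.3-fold lower number from compound 3 to compound 4 (0.10 log units; within the scatter). The hydrogen-bond acceptor counted for ethoxy can therefore go without a shift beyond the scatter, and on this read-out ethyl and ethoxy cannot be told apart at this position. Compound 4 also stands clear of the two larger ether-linked compounds, with a 5.0-fold lower number from compound 1 to compound 4 (0.70 log units; beyond the scatter) and a 16-fold lower number from compound 2 to compound 4 (1.20 log units; beyond the scatter), so the gaps seen with ethoxy persist when the small group carries no oxygen; no measurement at hand explains why the oxygen makes no readable difference here.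

On these data alone, what remains open is how far this tolerance extends at the same carbon, for example to a propyl chain, a dimethylamino group or a bare hydrogen. As far as these compounds go, it is also open whether the oxygen is equally dispensable with a larger group, as in benzyl or 2-phenylethyl in place of benzyloxy, or whether the match between ethyl and ethoxy holds once the chloro group is replaced by a bromo or methyl group.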